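This account rests on a few compounds, and the source may have more. Where it says the series, first, only, none or still open, it means among the compounds named here.

Measured compounds:
compound 1, `N#Cc1cnc(NCc2cnccc2C(F)(F)F)cc1N[C@H]1C[C@H](O)C1`, which gives 900 nM in an assay on isolated protein for inhibition of protein kinase C theta type (Homo sapiens), read by TR-FRET, with a stated time of 2 h; a lower number here means a stronger inhibitor, a higher number a weaker inhibitor
compound 2, `N#Cc1cnc(NCc2cncnc2C(F)(F)F)cc1N[C@H]1CC[C@@H](O)CC1`, which gives 450 nM in this assay
compound 3, `N#Cc1cnc(NCc2cncnc2-c2ccccc2)cc1N[C@H]1CC[C@@H](O)CC1`, which gives 90 nM in this assay

Compound 1 has the highest number of the three; compound 2 lies nearest to it, within the scatter, and compound 3 lies furthest, beyond it. Compound 4, `CC1(C)C[C@@H](Nc2cc(NCc3cnccc3C(F)(F)F)ncc2C#N)CC[C@H]1O`, differs from compound 1 by 4-hydroxy-3,3-dimethylcyclohexyl in place of 3-hydroxycyclobutyl on a nitrogen on an aromatic ring. For the measured compounds named here, the only measured step, a 5.0-fold lower number from compound 2 to compound 3 (0.70 log units; beyond the scatter), concerns a different place on the core and does not bear on this change. Going by the values given here, compounds 1 and 2 differ in two places at once, so their values show only that a hydroxycyclohexyl ring paired with another heteroaryl group sits within the scatter of compound 1. Nothing measured speaks to the 4-hydroxy-3,3-dimethylcyclohexyl group itself, so compound 4 is expected to move little, a 1.5-fold lower number from compound 1 to compound 4 (0.18 log units; within the scatter). Compound 4 is therefore estimated at 600 nM, between 150 nM and 2400 nM.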

Compound 4, half-maximal inhibitory concentration: 120 nM
Estimate against measurement, compound 4: 5.0-fold (0.70 log units) above; the whole stated range lies above it.
By their numbers in this assay, from the lowest: compounds 3 and 4 (each within the scatter of the next); then compounds 2 and 1 (each within the scatter of the next).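

Replacing 3-hydroxycyclobutyl with 4-hydroxy-3,3-dimethylcyclohexyl gives a 7.5-fold lower number from compound 1 to compound 4 (0.88 log units; beyond the scatter) in this assay and so shows that this place, on a nitrogen on an aromatic ring, responds to the group it carries, which no earlier single change had tested. The hydrogen-bond donor and acceptor counts stay the same across the change, while the ring and heavy-atom count grow. No available evidence explains the gain. The compounds shown leave open whether the larger ring or the two methyl groups carry this step, and whether an amine in place of the hydroxyl would keep it.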